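Methyl to Ethyl Across Two Matched Pairs

The source may hold more compounds than are shown below. What is called first, only, known or untested is meant among the compounds shown, and "the series" means these compounds.

Compound 1, `Cc1ccc2nc(NC(=O)NC(C)C)sc2c1`, gives 18500 nM in a functional assay (thoracic aorta, Rattus norvegicus, strain Wistar); on this read-out higher numbers stand for an effect only at larger amounts of compound and lower numbers for an effect already at smaller amounts.
Compound 2, `Cc1ccc2nc(NC(=S)NCc3ccccc3)sc2c1`, reaches only the limit of > 100000 nM in this assay; this is a limit of the assay, not a number.
Compound 3, `CCc1ccc2nc(NC(=O)NC(C)C)sc2c1`, gives 24400 nM in this assay.

The change from compound 1 to compound 3 is methyl in place of hydrogen on a saturated chain carbon bound to an aromatic carbon, and it made a 1.3-fold higher number from compound 1 to compound 3 (0.12 log units; within the scatter). The same change, at the same place, separates compound 2 from the not yet measured compound 4, `CCc1ccc2nc(NC(=S)NCc3ccccc3)sc2c1`: methyl in place of hydrogen on a saturated chain carbon bound to an aromatic carbon. The difference between the core of compound 1 and the core of compound 2 is not broken down here.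

The value for compound 2 is one of the limits in the limit of > 100000 nM in this assay, at which 1 of the 3 values shown sits. Among the measured compounds shown here, since the one measured instance of this change stayed within the scatter, the step from compound 2 to compound 4 is expected to be small as well, about a step that the limit leaves unreadable from compound 2 to compound 4 in this assay. Compound 4 is therefore estimated at 150000 nM, most likely again reported only as a limit, with a range from 50000 nM to 500000 nM.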

Compound 4, half-maximal effective concentration: > 100000 nM
Compound 4: a limit, no number; the forecaster's own chance of this, stated with the estimate: 80%; the middle value is on the limit's open side.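

Compound 4 gives > 100000 nM in this assay, which is a limit and not a number. Compound 2 is a limit as well, so no step between compound 2 and compound 4 can be read: the limit of > 100000 nM in this assay, at which 2 of the 4 values shown sit.

The compounds shown leave open whether methyl to ethyl changes the read-out on the core of compound 2 by more than the scatter.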